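Swapping a Ring for a Chain at the Ring Nitrogen

This account rests on a few compounds, and the source may have more. Where it says the series, first, only, none or still open, it means among the compounds named here.

Compound 1 `C=CCn1c(=O)n(C2CCC(CO)C2)c2nc(N)nc(O)c21`: 0%
Compound 2 `Cn1c(=O)n2c3c1c(=O)nc(N)n3CC1OC2[C@H](O)[C@@H]1O`: 0%

Of the compounds shown here, two have been tested in a functional assay on the whole organism with Mus musculus as the target; a higher number here means a larger maximal response, a lower number a smaller maximal response. In this assay compound 1 gives 0%, and compound 2 gives 0%. Compound 1 therefore stands level with compound 2 at the digits shown; the two values lie within the scatter of each other, so no order between them can be read.

Compound 3 `C=CCn1c(=O)n(CCCCO)c2nc(N)nc(O)c21` has not yet been measured. It differs from compound 1 in one place: a group of 5 heavy atoms (4 carbon, 1 oxygen; no ring) in place of a group of 7 heavy atoms (6 carbon, 1 oxygen; one five-membered non-aromatic ring of carbon only), on an aromatic nitrogen. For the measured compounds named here, both measured compounds show no response at all, and no step between measured compounds is known, so there is nothing to suggest that this change would open a response. The expected step from compound 1 to compound 3 is therefore none beyond the scatter, no change at the digits printed from compound 1 to compound 3 (within the scatter). In this assay compound 3 is estimated to give 0%, between 0% and 10%.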

Compound 3, largest response reached (reported as maximal response), in percent of the reference or control that the assay uses: 16%
Compound 3: middle estimate off by 16 percentage points, on the low side; measured number above the stated range.
By their numbers in this assay, from the lowest: compounds 1 and 2 (each within the scatter of the next); then compound 3.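

In this assay the open 4-hydroxybutyl chain in place of the five-membered carbon ring on the aromatic nitrogen brings a number 16 percentage points higher from compound 1 to compound 3 (beyond the scatter) while the rest of the core stays the same. This position therefore does affect the response, and the core of compound 1 can give a measurable response once this group is changed, even though the counts of hydrogen-bond donors and acceptors in the group stay the same. No measurement here gives a reason for the step.

The change removes the ring and also shortens the group, so these two parts of the change cannot be told apart. From the compounds shown here alone, it also remains open whether a longer chain, or a chain ending in an amine or a carboxylic acid instead of the hydroxyl, would raise the response further or lose it.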